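Swapping the Dichlorophenyl Amide for a Trifluoromethylphenyl Amide

The source may hold more compounds than are shown below. What is called first, only, known or untested is meant among the compounds shown, and "the series" means these compounds.

Compound 1 `COc1cc(Cl)cc(-c2nn(-c3cccc(NC(=O)c4ccc(Cl)c(Cl)c4)c3)cc2-c2ccncc2)c1` is tested in a functional assay on SK-MEL-2 cells (Homo sapiens) for inhibition, read by sulforhodamine B assay, with a stated time of 48 h, tested at 10 uM (on this read-out higher numbers stand for a weaker effect at the one concentration tested and lower numbers for a stronger effect), and gives 78.4%. Of the two measured compounds this is the higher number, so compound 1 shows the weaker effect. Compound 2 `COc1cc(Cl)cc(-c2nn(-c3cccc(NC(=O)Nc4cc(C(F)(F)F)cc(C(F)(F)F)c4)c3)cc2-c2ccncc2)c1` gives -38.1% in this assay, far below compound 1. Compound 3 `COc1cc(Cl)cc(-c2nn(-c3cccc(NC(=O)c4cccc(C(F)(F)F)c4)c3)cc2-c2ccncc2)c1` awaits measurement and differs from compound 1 in one place: 3-(trifluoromethyl)phenyl in place of 3,4-dichlorophenyl on a carbonyl carbon. Among the compounds with values here, no measured pair shows this exact change, so only a small step is expected, a number 8.4 percentage points lower from compound 1 to compound 3 (within the scatter), barely beyond the usual scatter if at all. Compound 3 is therefore expected to give about 70%, likely between 40% and 100%.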

Compound 3, a percentage reported as activity, at one concentration (the size of the read-out at that concentration, not a potency): 56.4%
Estimate against measurement, compound 3: 13.6 percentage points above; low and high end bracket the measured number.
By their numbers in this assay, from the lowest: compound 2; then compound 3; then compound 1.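

Placing 3-(trifluoromethyl)phenyl in place of 3,4-dichlorophenyl on a carbonyl carbon gives a number 22 percentage points lower from compound 1 to compound 3 (beyond the scatter) in this assay, a modestly stronger effect. Within the data shown here, this is the first single-place comparison, and it shows that changing only this aromatic group, with the amide kept, can move the read-out beyond the usual scatter. Nothing measured here explains the step.

As far as these compounds go, it remains open how this position would respond to a nitrile or an amine on the phenyl ring, or to an unsubstituted phenyl group.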